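The source may report more compounds than this note shows. Statements on the series, on what has been measured and on what is new or still open speak of the compounds shown alone.

Measured so far in a functional assay on PC-3 cells (Homo sapiens) for cytotoxicity, read by XTT assay, with a stated time of 72 h; a higher number here means a weaker inhibitor, a lower number a stronger inhibitor:
- compound 1, `CCN(CC)C(=O)c1ccc(-c2cc(C3=CC(=O)C=CC3=O)no2)s1`: 8900 nM
- compound 2, `COc1ccc(OC)c(-c2cc(-c3ccc(C(=O)N(C)Cc4ccccc4)s3)on2)c1`: > 30000 nM

Compound 1 carries a diethylamide on the thiophene of the shared core and gives 8900 nM in this assay. Of the two results shown, this is the only one that is a number. For compound 2, `COc1ccc(OC)c(-c2cc(-c3ccc(C(=O)N(C)Cc4ccccc4)s3)on2)c1`, the result > 30000 nM is a limit of this assay, not a number; compound 2 thus sits at the limit of > 30000 nM in this assay, at which 1 of the 2 values shown sits. Among the measured compounds shown here, compound 1 therefore stands alone as the single measured value, with no step between measured compounds available for comparison.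

The next compound, compound 3, `CN(Cc1ccc(F)cc1)C(=O)c1ccc(-c2cc(C3=CC(=O)C=CC3=O)no2)s1`, keeps the core and the quinone of compound 1 and changes the amide: (4-fluorobenzyl)(methyl)amino in place of diethylamino on a carbonyl carbon. Nothing measured speaks to this particular amide change on the quinone core, so the expected step is small and its direction open. The step from compound 1 to compound 3 is estimated at a 1.1-fold higher number from compound 1 to compound 3 (0.05 log units; within the scatter), no further than the scatter of repeated measurements. Compound 3 is accordingly expected to give about 10000 nM, within a range of 3000 nM to 30000 nM.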

Compound 3, half-maximal inhibitory concentration: > 30000 nM
Compound 3 was reported as a limit; the forecaster's own chance of this, stated with the estimate: 25%; middle value at least 3.0-fold (0.47 log units) from the limit.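

In this assay, among the compounds shown here, the amide on the carbonyl carbon proves to be a place where the read-out responds on the core of compound 1, which the earlier compounds could not show, since no step between them was available: (4-fluorobenzyl)(methyl)amino in place of diethylamino gives an at least 3.3-fold higher number from compound 1 to compound 3 (0.52 log units; beyond the scatter). Compound 3 gives > 30000 nM, which is a limit of the assay and not a number, so the step has a lower bound only. The series now holds more limits than numbers, and diethylamino is the only amide group shown with a measured value: the limit of > 30000 nM in this assay, at which 2 of the 3 values shown sit.

Going by these compounds, a single step cannot tell whether the weaker result goes with the aromatic ring, the fluorine or the methyl on the amide nitrogen, and how far the result lies past the limit stays unknown. Still open, on these data alone, is how the core of compound 1 responds to a cyclic amide such as morpholine or to a chain ending in a basic amine or a carboxylic acid on the carbonyl carbon.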